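From an Amine Chain to a Sulfonyloxy Group

A few compounds are considered here, and "the series" means these few. Any claim that something is new, unique, unknown or untested is made for them only; others in the source may bear on it.

In a functional assay on HCT-116 cells (Homo sapiens) for cytotoxicity, read by MTT assay, with a stated time of 72 h (on this read-out higher numbers stand for weaker inhibition and lower numbers for stronger inhibition), compound 1 `Nc1ccc(Nc2c(C(=O)NCc3ccc(F)cc3)nc(Br)c3cccnc23)cc1`, which carries 4-aminophenyl on a nitrogen, gives 7000 nM. Compound 2 `C[C@H](Nc1c(C(=O)NCc2ccc(F)cc2)nc(Br)c2cccnc12)c1ccccc1`, with 1-phenylethyl there, is recorded only as a limit, > 20000 nM. Compound 3 `CNCCCNc1c(C(=O)NCc2ccc(F)cc2)nc(Br)c2cccnc12`, with 3-(methylamino)propyl, is likewise recorded only as a limit, > 10000 nM, so it has no exact number.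

Compound 4 `Cc1ccc(S(=O)(=O)Oc2c(C(=O)NCc3ccc(F)cc3)nc(Br)c3cccnc23)cc1` places ((4-methylphenyl)sulfonyl)oxy in place of (3-(methylamino)propyl)amino on an aromatic carbon. Going by the values given here, three measured steps bear on this only indirectly, since each exchanges a group on the nitrogen and none removes that nitrogen. The first is an at least 2.8-fold higher number from compound 1 to compound 2 (0.45 log units; beyond the scatter). The second is an at least 1.4-fold higher number from compound 1 to compound 3 (0.15 log units; that floor lies within the scatter). The third is a step that the two limits leave unreadable from compound 2 to compound 3.

These steps give no measured guide to the direction of the new change, so no clear shift beyond the scatter is expected in this assay. The expected step is a step that the limit leaves unreadable from compound 3 to compound 4. Compound 4 is estimated at 12000 nM, within an expected range of 4000 nM to 30000 nM.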

Compound 4, half-maximal inhibitory concentration: > 20000 nM
Compound 4 ended at the assay's limit (the forecaster's own chance of this, stated with the estimate: 40%); middle value at least 1.6-fold (0.22 log units) away from the limit.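

With ((4-methylphenyl)sulfonyl)oxy on this aromatic carbon, the nitrogen that carried every earlier group is gone, and in this assay compound 4 still gives only a limit, not a number: the limit of > 20000 nM in this assay, at which 2 of the 4 values shown sit.

Against the 4-aminophenyl group on nitrogen, this exchange gives an at least 2.8-fold higher number from compound 1 to compound 4 (0.45 log units; beyond the scatter), so this group without a nitrogen does not reach the one exact value shown. The steps that link compound 4 to compound 2 and compound 3 cannot be read, as both ends of each are limits.

From the compounds shown here alone, it stays open whether a group joined through oxygen can give an exact value at this position at all. A phenoxy group, or a plain phenyl on the nitrogen, would help separate the part played by the linking atom from that of the amine on the 4-aminophenyl ring.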